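Replacing the 4-fluorophenyl of compound 3

This account rests on a few compounds, and the source may have more. Where it says the series, first, only, none or still open, it means among the compounds named here.

In a functional assay on A2780 cells (Homo sapiens) for antiproliferative activity, read by MTT assay, with a stated time of 48 h (on this read-out higher numbers stand for weaker inhibition and lower numbers for stronger inhibition), the values are:
compound 1 `Cc1c(Cc2ccccc2)c(=O)oc2cc(OCCOc3no[n+]([O-])c3S(=O)(=O)c3ccccc3)ccc12` gives 12.7 nM
compound 2 `COCCOc1no[n+]([O-])c1S(=O)(=O)c1ccccc1` gives 1640 nM
compound 3 `Cc1c(Cc2ccc(F)cc2)c(=O)oc2cc(OCCOc3no[n+]([O-])c3S(=O)(=O)c3ccccc3)ccc12` gives 6.6 nM

Compound 3 at 6.6 nM lies within the scatter of compound 1 and far under compound 2. Compound 4 `CNS(=O)(=O)Nc1cccc(Cc2c(C)c3ccc(OCCOc4no[n+]([O-])c4S(=O)(=O)c4ccccc4)cc3oc2=O)c1` carries 3-((methylsulfamoyl)amino)phenyl in place of 4-fluorophenyl on a saturated chain carbon bound to an aromatic carbon and has not yet been measured. Going by the values given here, the only measured step on that ring is a 1.9-fold lower number from compound 1 to compound 3 (0.28 log units; within the scatter) with fluoro in place of hydrogen on an aromatic carbon. That swap is far smaller than the present one, so it guides only weakly. A modest rise in the number is expected, perhaps none beyond the scatter. The estimated step is a 2.3-fold higher number from compound 3 to compound 4 (0.36 log units; beyond the scatter) in this assay here. For compound 4 the expected value is 15 nM with an estimated range from 4 nM to 60 nM overall.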

Compound 4, half-maximal inhibitory concentration: 10.2 nM
Beside the measured number, compound 4's estimate is 1.5-fold (0.17 log units) above it, and the stated range covers the measured number.
By their numbers in this assay, from the lowest: compounds 3, 4 and 1 (each within the scatter of the next); then compound 2.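

In this assay, the aromatic ring on the saturated chain carbon accepts a much larger substituent carrying hydrogen-bond donors and acceptors, not just a fluoro, without a shift beyond the scatter: there is a 1.5-fold higher number from compound 3 to compound 4 (0.19 log units; within the scatter), and a 1.2-fold lower number from compound 1 to compound 4 (0.10 log units; within the scatter). So at this position, the added (methylsulfamoyl)amino leaves the antiproliferative read-out unmoved. Nothing available explains this insensitivity.

Going by these compounds, whether a carboxylic acid or a primary amine in place of (methylsulfamoyl)amino would also stay within the scatter remains open. How large a group this position accepts before the number moves is also unsettled.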